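Swapping oxiran-2-yl for vinyl on compound 1

A few compounds are considered here, and "the series" means these few. Any claim that something is new, unique, unknown or untested is made for them only; others in the source may bear on it.

In a functional assay on HepG2 cells (Homo sapiens) for cytotoxicity, read by sulforhodamine B assay, with a stated time of 48 h (on this read-out lower numbers stand for stronger inhibition and higher numbers for weaker inhibition), compound 1 (`N#Cc1c(-c2ccc(Cl)cc2)cc(-c2ccc(Cl)cc2)n(CC2CO2)c1=O`) gives 6.2 ug/mL and compound 2 (`CC(=O)OC[C@H]1O[C@@H](n2c(-c3ccc(Cl)cc3)cc(-c3ccc(Cl)cc3)c(C#N)c2=O)[C@H](OC(C)=O)[C@@H](OC(C)=O)[C@@H]1OC(C)=O`) gives 7.25 ug/mL so far. These two values lie within the usual scatter of each other, so compound 1 stands level with compound 2 on the numbers available.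

Compound 3 (`C=CCn1c(-c2ccc(Cl)cc2)cc(-c2ccc(Cl)cc2)c(C#N)c1=O`) has not yet been measured. It keeps the core of compound 1 and differs from it in one place (vinyl in place of oxiran-2-yl on a saturated chain carbon bound to an aromatic nitrogen): vinyl in place of oxiran-2-yl on a saturated chain carbon bound to an aromatic nitrogen. The same difference also reads as (oxiran-2-yl)methyl to allyl.

Within the data shown here, no two measured compounds differ in one place only, so nothing measured sizes this change directly, and the expectation rests on compound 1 at 6.2 ug/mL as its starting point. The expected step is small, an estimated change (a 1.3-fold higher number from compound 1 to compound 3 (0.11 log units; within the scatter)) that stays within the scatter in this assay and has no firm direction. For compound 3 the estimated value is 8 ug/mL with an expected range from 3.5 ug/mL to 18 ug/mL on this estimate.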

Compound 3, half-maximal inhibitory concentration: 20 ug/mL
Compound 3: middle estimate off by 2.5-fold (0.40 log units), on the low side, outside the stated range (above it).
By their numbers in this assay, from the lowest: compounds 1 and 2 (each within the scatter of the next); then compound 3.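

Replacing oxiran-2-yl with vinyl on a saturated chain carbon bound to an aromatic nitrogen gives a 3.2-fold higher number from compound 1 to compound 3 (0.51 log units; beyond the scatter) in this assay, which shows that the read-out responds to what this place carries. Among these compounds, this is the only change in the set that can be sized directly, since no earlier pair of measured compounds differed in one place only. The modest step comes with the loss of the three-membered ring and its oxygen, but no measurement at hand explains why the number rises.

The compounds shown cannot separate the part played by the ring from that played by the oxygen, nor can they say whether the vinyl group itself contributes to the higher number, and a single step gives no trend. Going by these compounds, it also remains open how a simple propyl group, a longer chain, an amine or a carboxylic acid would read in this place on the core of compound 1 in this assay.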